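The source may hold more compounds than are shown below. What is called first, only, known or untested is meant among the compounds shown, and "the series" means these compounds.

In a functional assay on HeLa cells (Homo sapiens) for inhibition, read by cell counting, with a stated time of 4 days (on this read-out lower numbers stand for stronger inhibition and higher numbers for weaker inhibition), compound 2 `C=C(Br)C(=O)Nc1cccc(-c2cn3nc(Cc4ccccc4)sc3n2)c1` gives 4500 nM, the lowest of the two numbers measured. Its nearest neighbour is compound 3 `Nc1cccc(-c2cn3nc(Cc4ccccc4)sc3n2)c1`, which in this assay gives 24000 nM; that step is a 5.3-fold higher number from compound 2 to compound 3 (0.73 log units; beyond the scatter). Compound 1 `Nc1cccc(-c2cn3nc(-c4cccs4)sc3n2)c1` in this assay reaches only a limit, > 250000 nM, as recorded in the limit of > 250000 nM in this assay, at which 1 of the 3 values shown sits. Between these two compounds the step is an at least 10-fold lower number from compound 1 to compound 3 (1.01 log units; beyond the scatter), the change being benzyl in place of thiophen-2-yl on an aromatic carbon.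

Compound 4 `C=C(Br)C(=O)Nc1cccc(-c2cn3nc(-c4ccc(C)cc4)sc3n2)c1` has not yet been measured. It differs from compound 2 in one place: 4-methylphenyl in place of benzyl on an aromatic carbon. The step from compound 1 to compound 3 bears directly on it, since it swaps a directly attached aromatic ring for benzyl at the same carbon and lowered the number strongly; the change toward compound 4 runs the other way, putting a directly attached aromatic ring back in place of benzyl. Compound 4 is therefore expected to give a higher number than compound 2, with the step from compound 2 to compound 4 estimated as an 8.9-fold higher number from compound 2 to compound 4 (0.95 log units; beyond the scatter). For compound 4 the estimated value in this assay is 40000 nM, expected to lie between 10000 nM and 200000 nM.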

Compound 4, half-maximal inhibitory concentration: 2000 nM
Beside the measured number, compound 4's estimate is 20-fold (1.30 log units) above it; measured number below the stated range.
By their numbers in this assay, from the lowest: compound 4; then compound 2; then compound 3. At a limit, above all of these: compound 1.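

In this assay, 4-methylphenyl in place of benzyl gives a 2.3-fold lower number from compound 2 to compound 4 (0.35 log units; beyond the scatter). With the (1-bromoethenyl)carbonyl group on the nitrogen, then, a directly attached aromatic ring at this carbon does not raise the number, something the earlier step, an at least 10-fold lower number from compound 1 to compound 3 (1.01 log units; beyond the scatter), taken with thiophen-2-yl and a free amine, could not show. The two groups exchanged here have the same atoms, joined differently, and the earlier step does not carry over to this pair; nothing shown gives a reason for the difference.

On these data alone, whether the lower number of compound 4 goes with the direct attachment of the ring or with its methyl stays open, and a plain phenyl at this carbon would separate the two. Also open, as far as these compounds go, are how the free amine reads with 4-methylphenyl in this place, and how a longer chain or a carboxylic acid on that ring, or a plain acetyl on the nitrogen in place of the (1-bromoethenyl)carbonyl group, would read in this assay.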